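Dropping the methyl from the anilino ring: compound 4 expected

The source may hold more compounds than are shown below. What is called first, only, known or untested is meant among the compounds shown, and "the series" means these compounds.

Compound 1 `COc1cc(/C=C/C(=O)c2sc(Nc3ccccc3C)nc2C)cc(OC)c1OC` gives in a functional assay on PC-3 cells (Homo sapiens) for cytotoxicity, read by MTT assay (on this read-out lower numbers stand for stronger inhibition and higher numbers for weaker inhibition), a value of > 25000 nM, which is a limit of the assay rather than a number.
Compound 2 `COc1cc(/C=C/C(=O)c2sc(Nc3ccc(C)cc3)nc2C)cc(OC)c1OC` gives in this assay the limit > 25000 nM.
Compound 3 `COc1cc(/C=C/C(=O)c2sc(Nc3cccc(C)c3)nc2C)cc(OC)c1OC` gives in this assay the limit > 25000 nM.

All three compounds share one core and differ only in where the methyl sits on the ring attached to the nitrogen. Compound 3 stands at the same limit as the other two, so it cannot be placed above or below them. The steps measured so far, a step that the two limits leave unreadable from compound 1 to compound 2, a step that the two limits leave unreadable from compound 1 to compound 3 and a step that the two limits leave unreadable from compound 2 to compound 3, are all unreadable, because the limit of > 25000 nM in this assay, at which 3 of the 3 values shown sit, hides every difference between them.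

Compound 4 `COc1cc(/C=C/C(=O)c2sc(Nc3ccccc3)nc2C)cc(OC)c1OC` is not yet measured. It differs from compound 3 by hydrogen in place of methyl on an aromatic carbon, on an aromatic carbon of a six-membered aromatic ring of carbon only, meta to a large group; cut one bond further out this reads 3-methylphenyl to phenyl.

Among the measured compounds shown here, no measured step says anything about removing a methyl from this ring, so no direction beyond the scatter is expected for a step that the limit leaves unreadable from compound 3 to compound 4. Since compound 3 sits at the limit of > 25000 nM, compound 4 is expected to give about 30000 nM in this assay, within 8000 nM to 120000 nM, most likely again reported only as a limit.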

Compound 4, half-maximal inhibitory concentration: > 25000 nM
Compound 4: a limit, no number; the forecaster's own chance of this, stated with the estimate: 80%; the middle value is on the limit's open side.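

Compound 4 sits at the same limit as compound 1, compound 2 and compound 3, so none of its steps to them can be read, because one ceiling hides any difference: the limit of > 25000 nM in this assay, at which 4 of the 4 values shown sit.

Whether moving or removing this methyl changes activity at all stays open, as every result shown in this assay is a limit.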